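Positional Isomer of Compound 1 at the Amide Nitrogen

A few compounds are considered here, and "the series" means these few. Any claim that something is new, unique, unknown or untested is made for them only; others in the source may bear on it.

Compound 1 `COc1ccc(N2C(=O)COc3ccc(-c4cnc5ccccc5c4)cc32)cc1`: > 40000 nM
Compound 2 `COc1ccc(N2C(=O)COc3ccc(-c4cnc(OC)c(NS(=O)(=O)c5ccc(F)cc5)c4)cc32)cc1`: 18400 nM
Compound 3 `COc1ccc(N2C(=O)COc3ccc(-c4ccc(O)cc4)cc32)cc1`: > 40000 nM

In a functional assay on A-375 cells (Homo sapiens) for antiproliferative activity, read by MTT assay, with a stated time of 72 h (on this read-out higher numbers stand for weaker inhibition and lower numbers for stronger inhibition), compound 1 gives only a limit, > 40000 nM, so no number is known for it. Compound 3 likewise reaches only a limit in this assay, > 40000 nM. For the measured compounds named here, compound 2 is the one measured compound with a number, 18400 nM. The wider picture is the limit of > 40000 nM in this assay, at which 2 of the 3 values shown sit.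

Compound 4 `COc1cccc(N2C(=O)COc3ccc(-c4cnc5ccccc5c4)cc32)c1` has the same atoms as compound 1, joined differently: 3-methoxyphenyl in place of 4-methoxyphenyl on an amide-type nitrogen in a ring. Going by the values given here, no step between measured compounds is known, and nothing among the measured compounds speaks for a change beyond the scatter from this rearrangement. Compound 4 is therefore expected to give 45000 nM, estimated to lie between 15000 nM and 150000 nM. That estimate amounts to an expected step that the limit leaves unreadable from compound 1 to compound 4, most likely again reported only as a limit.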

Compound 4, half-maximal inhibitory concentration: 23600 nM
The estimate for compound 4 lay 1.9-fold (0.28 log units) above the measured number; the measured number falls inside the stated range.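

With 3-methoxyphenyl in place of 4-methoxyphenyl on the amide-type nitrogen in a ring, this assay gives a number for compound 4, 23600 nM. Compound 1 has only a limit, > 40000 nM. This gives an at least 1.6-fold lower number from compound 1 to compound 4 (0.22 log units; that floor lies within the scatter), so the rearrangement can be read only as a floor, not as a change of known size.

On these data alone, it remains open whether an amine or a carboxylic acid in place of the methoxy group would shift the number. As far as these compounds go, it is also open whether the same rearrangement would matter alongside the other groups of compound 2 or compound 3.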